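Fluoro for methyl exchange: expectation for compound 4

The source may hold more compounds than are shown below. What is called first, only, known or untested is meant among the compounds shown, and "the series" means these compounds.

Measured so far in an assay on HepG2 cells for activation of nuclear factor erythroid 2-related factor 2 (Homo sapiens), read by a luciferase reporter, with a stated time of 5 h; on this read-out lower numbers stand for an effect already at smaller amounts and higher numbers for an effect only at larger amounts of compound:

compound 1 `Cc1ccc(/C=C/c2cccc(F)c2)cc1` gives 800 nM
compound 2 `Fc1ccc(/C=C/c2cccc(F)c2)cc1` gives 650 nM
compound 3 `Cc1ccc(/C=C/c2ccc(F)cc2F)cc1` gives 2000 nM

Compound 2 differs from compound 1 in one place: fluoro in place of methyl on an aromatic carbon. On this assay the step is a 1.2-fold lower number from compound 1 to compound 2 (0.09 log units; within the scatter), so the two values are not told apart here.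

Compound 3 gives the highest of the three numbers. Against compound 1 the gap is beyond the scatter, and against compound 2 it is larger still. How the core of compound 3 differs from the core of compound 1 is not broken down here.

Compound 4 `Fc1ccc(/C=C/c2ccc(F)cc2F)cc1` has not yet been measured. It differs from compound 3 in one place: fluoro in place of methyl on an aromatic carbon. For the measured compounds named here, this is the same kind of change as the one from compound 1 to compound 2, though the surroundings of the place are described differently: in compound 4 the group sits para to a large group, in compound 2 para to a group of 9 heavy atoms.

For this assay the expected step is a 1.2-fold lower number from compound 3 to compound 4 (0.07 log units; within the scatter), which rests on the step of a 1.2-fold lower number from compound 1 to compound 2 (0.09 log units; within the scatter) for the same kind of change, and on compound 3 giving 2000 nM as the starting point. Going by the values given here, only one earlier instance of the change is available, so the range is kept wide.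

The estimate for compound 4 in this assay is 1700 nM, expected to lie between 800 nM and 4000 nM.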

Compound 4, half-maximal effective concentration: 900 nM
Beside the measured number, compound 4's estimate is 1.9-fold (0.28 log units) above it; the range from low to high includes it.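

In this assay, fluoro in place of methyl on an aromatic carbon gives a 2.2-fold lower number from compound 3 to compound 4 (0.35 log units; beyond the scatter), a modest step, whereas the same exchange on the other core stays within the scatter. Read alone, those two results could suggest that the core matters, but the two steps cannot be told apart, so the change carries from one core to the other without a demonstrated difference: the same change on two cores in this assay, a 1.2-fold lower number (0.09 log units; within the scatter) from compound 1 to compound 2 and a 2.2-fold lower number (0.35 log units; beyond the scatter) from compound 3 to compound 4, 1.8-fold (0.26 log units) apart, within the scatter of two such steps. For the compounds shown here, this rests on only two pairs in one assay, so it shows agreement between the core of compound 1 and the core of compound 3, but it neither fixes a step size that would hold on further cores nor explains why the step occurs.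

As far as these compounds go, whether a chloro, methoxy or trifluoromethyl group on the same aromatic carbon would behave alike on both cores remains open. Also open is whether the fluoro for methyl exchange would keep the same size on a core that carries an amine or a carboxylic acid elsewhere, since the compounds shown bear only methyl and fluoro groups.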